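Swapping the anilino substituent on a shared quinazoline-like core

The source may report more compounds than this note shows. Statements on the series, on what has been measured and on what is new or still open speak of the compounds shown alone.

Of the compounds shown here, two sharing one core have been measured in a functional assay on MCF7 cells (Homo sapiens) for antiproliferative activity, read by MTT assay, with a stated time of 72 h; on this read-out lower numbers stand for stronger inhibition and higher numbers for weaker inhibition. Compound 1, `Cn1cc(-c2ccc3ncnc(Oc4ccc5ncccc5c4)c3c2)cn1`, gives 22000 nM in this assay. Compound 2, `Cn1cc(-c2ccc3ncnc(Nc4ccc(F)c(Cl)c4)c3c2)cn1`, gives 52200 nM in this assay, the higher of the two numbers; the gap to compound 1 lies beyond the usual scatter, so compound 2 is the weaker of the pair.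

Compound 3, `C#Cc1cccc(Nc2ncnc3ccc(-c4cnn(C)c4)cc23)c1`, differs from compound 2 in a single place: 3-ethynylphenyl in place of 3-chloro-4-fluorophenyl on a nitrogen on an aromatic ring. One aromatic ring of carbon replaces another of the same size, with a triple bond outside the ring where the halogens were. Among the measured compounds shown here, no measured pair shows this exchange, so its effect is unknown. The step from compound 2 to compound 3 is expected to be modest, a 1.5-fold lower number from compound 2 to compound 3 (0.17 log units; within the scatter), likely not beyond the scatter in either direction. Compound 3 is therefore expected to give about 35000 nM in this assay, within a range from 9000 nM to 130000 nM.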

Compound 3, half-maximal inhibitory concentration: 11400 nM
For compound 3 the middle estimate is 3.1-fold (0.49 log units) above the measured one, and the stated range covers the measured number.
By their numbers in this assay, from the lowest: compounds 3 and 1 (each within the scatter of the next); then compound 2.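

At this place, on a nitrogen on an aromatic ring, the choice of group matters: 3-ethynylphenyl in place of 3-chloro-4-fluorophenyl gives a 4.6-fold lower number from compound 2 to compound 3 (0.66 log units; beyond the scatter) in this assay. Both groups have the same number of heavy atoms and the same six-membered aromatic ring of carbon, so even an exchange that keeps the ring and swaps only what hangs on it can shift the number beyond the scatter. No measurement at hand accounts for this shift.

From the compounds shown here alone, the exchange removes the chlorine and the fluorine and adds the triple bond in one step, so the share of each remains unknown. Also open, going by these compounds, is how the number would respond to an amine or a carboxylic acid on this ring, or to a longer chain in place of the ethynyl group.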